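Chlorophenyl in place of fluoromethoxyphenyl: an expected value

This account rests on a few compounds, and the source may have more. Where it says the series, first, only, none or still open, it means among the compounds named here.

Compound 1 `COc1ccc(/C=C/C(=O)c2ccc(OC)c3c2OC(C)(C)C=C3)c(F)c1` gives 6570 nM in a functional assay on SW-620 cells (Homo sapiens) for antiproliferative activity, read by MTT assay, with a stated time of 24 h (on this read-out lower numbers stand for stronger inhibition and higher numbers for weaker inhibition), the highest of the two numbers shown there. Its nearest neighbour is compound 2 `COc1ccc(C(=O)/C=C/c2ccc([N+](=O)[O-])cc2)c2c1C=CC(C)(C)O2`, which gives 3520 nM in this assay; the step of a 1.9-fold lower number from compound 1 to compound 2 (0.27 log units; within the scatter). Compound 3 `COc1ccc(C(=O)/C=C/c2ccc(C(F)(F)F)cc2)c2c1C=CC(C)(C)O2` is reported in this assay only as a limit, > 10000 nM. The step of an at least 2.8-fold higher number from compound 2 to compound 3 (0.45 log units; beyond the scatter). Compound 4 `COc1ccc(C(=O)/C=C/c2ccc(Cl)cc2)c2c1C=CC(C)(C)O2` differs from compound 1 in one place: 4-chlorophenyl in place of 2-fluoro-4-methoxyphenyl on a double-bonded chain carbon bound to a double-bonded chain carbon. Both measured steps vary this same aryl group and run in opposite directions, one within the scatter and one beyond it, so no clear direction is carried over. Compound 4 is therefore expected to stay close to compound 1, with a 1.1-fold lower number from compound 1 to compound 4 (0.04 log units; within the scatter). The value of compound 4 in this assay is estimated at 6000 nM, between 2500 nM and 15000 nM.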

Compound 4, half-maximal inhibitory concentration: > 10000 nM
Compound 4: a limit, no number; the forecaster's own chance of this, stated with the estimate: 25%; at least 1.6-fold (0.22 log units) between middle value and limit.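

In this assay compound 4 is reported only as a limit, not a number. Chloro in place of nitro on an aromatic carbon gives an at least 2.8-fold higher number from compound 2 to compound 4 (0.45 log units; beyond the scatter), and 4-chlorophenyl in place of 2-fluoro-4-methoxyphenyl gives an at least 1.5-fold higher number from compound 1 to compound 4 (0.18 log units; that floor lies within the scatter), so only the first of these steps clearly separates the compounds. The step between compound 3 and compound 4 cannot be read, since both stand at a limit: the limit of > 10000 nM in this assay, at which 2 of the 4 values shown sit.

As far as these compounds go, how far compound 3 and compound 4 lie beyond that limit stays open. So does whether an amine or a carboxylic acid on that aromatic carbon would give a number in this assay.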